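A few compounds are considered here, and "the series" means these few. Any claim that something is new, unique, unknown or untested is made for them only; others in the source may bear on it.

Going by the values given here, in a functional assay on HeLa cells (Homo sapiens) for antiproliferative activity, read by MTT assay, with a stated time of 48 h (a higher number here means a weaker inhibitor, a lower number a stronger inhibitor), compound 1 (`COc1ccc(C(=O)c2ccc(OC)c3c2OC(C)(C)C=C3)c(NC(=O)CO)c1`) gives 100 nM and holds the lower of the two numbers measured so far, which makes it the stronger inhibitor. Compound 2 (`CNCC(=O)Nc1cc(OC)ccc1C(=O)c1ccc2c(c1)C=CC(C)(C)O2`) gives 970 nM in the same test, a gap beyond the usual scatter. Compound 3 (`COc1ccc(C(=O)c2ccc(OC)c3c2OC(C)(C)C=C3)c(NC(=O)CN(C)C)c1`) keeps the core of compound 1 and changes one group, with dimethylamino in place of hydroxy on a saturated chain carbon bound to a carbonyl carbon. Among the compounds with values here, no measured pair shows this change alone. Within the data shown here, the only hint is compound 2 at 970 nM with an amine on such a chain, though it also differs elsewhere. A moderate loss of strength in this assay is therefore expected, probably beyond the scatter. The expected change is a 3.0-fold higher number from compound 1 to compound 3 (0.48 log units; beyond the scatter) and remains uncertain. For compound 3 the estimated value is 300 nM within a range from 70 nM to 1300 nM in this test.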

Compound 3, half-maximal inhibitory concentration: 1050 nM
Compound 3: middle estimate off by 3.5-fold (0.54 log units), on the low side; the measured number falls inside the stated range.
By their numbers in this assay, from the lowest: compound 1; then compounds 2 and 3 (each within the scatter of the next).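

In this assay, going by these compounds alone, the swap of hydroxy for dimethylamino on a saturated chain carbon bound to a carbonyl carbon gives an 11-fold higher number from compound 1 to compound 3 (1.02 log units; beyond the scatter) with the rest of the molecule unchanged, the first direct reading of this change. The group at this position therefore matters for the number in this test, and the step is large. The swap trades 1 heavy atom for 3 and 1 hydrogen-bond donor for 0 hydrogen-bond donors, but nothing measured here links the loss to either difference or to any other cause.

Going by these compounds, it remains open whether hydroxy is specifically favoured here or dimethylamino specifically disfavoured. A methoxy group, a primary amine or a longer chain ending in hydroxy at this position could help separate those two readings.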